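Benzylsulfanyl purine nucleosides: ring substituent swap, compound 3

The source may report more compounds than this note shows. Statements on the series, on what has been measured and on what is new or still open speak of the compounds shown alone.

Measured so far:
compound 1 `OC[C@H]1O[C@@H](n2cnc3c(SCc4cccc(Br)c4)ncnc32)[C@H](O)[C@@H]1O` — 20.5 nM
compound 2 `OC[C@H]1O[C@@H](n2cnc3c(SCc4ccc(Cl)cc4)ncnc32)[C@H](O)[C@@H]1O` — 14.2 nM

Compound 2 sits at the lowest of the two numbers in an assay on K562 cells for displacement of a labelled ligand from Equilibrative nucleoside transporter 1 (Homo sapiens) (on this read-out lower numbers stand for stronger inhibition and higher numbers for weaker inhibition), but only by a 1.4-fold lower number from compound 1 to compound 2 (0.16 log units; within the scatter), so nothing separates it from compound 1 beyond the scatter. Compound 3 `OC[C@H]1O[C@@H](n2cnc3c(SCc4cccc(I)c4)ncnc32)[C@H](O)[C@@H]1O` carries 3-iodophenyl in place of 4-chlorophenyl on a saturated chain carbon bound to a sulfur. Going by the values given here, the one step that bears on this change is the earlier exchange of one substituted phenyl for another at the same place, a 1.4-fold lower number from compound 1 to compound 2 (0.16 log units; within the scatter), which stayed within the scatter. With a single comparable step of that size, the expectation for this assay is no shift beyond the scatter, in either direction. Compound 3 is therefore expected near compound 2, with an estimated step of a 1.2-fold higher number from compound 2 to compound 3 (0.08 log units; within the scatter). The estimate for compound 3 in this assay is 17 nM, with a range from 7 nM to 40 nM.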

Compound 3, inhibition constant: 13.8 nM
The estimate for compound 3 lay 1.2-fold (0.09 log units) above the measured number; the measured number falls inside the stated range.
By their numbers in this assay, from the lowest: compounds 3, 2 and 1 (each within the scatter of the next).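

In this assay, the exchange of 4-chlorophenyl for 3-iodophenyl on a saturated chain carbon bound to a sulfur, which alters both the halogen and its place, stays within the scatter (a 1.0-fold lower number from compound 2 to compound 3 (0.01 log units; within the scatter)). Iodo in place of bromo on an aromatic carbon is the first change of the halogen alone, and it also stays within the scatter (a 1.5-fold lower number from compound 1 to compound 3 (0.17 log units; within the scatter)), so the three halogenated benzyl groups shown cannot be told apart on this read-out. No accompanying data bear on why these values stay so close.

Every compound shown carries a single halogen, so it remains open whether a carboxylic acid or an amine in place of that halogen would move the number beyond the scatter. The same question stands for a phenethyl group in place of the benzyl group.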